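The source may report more compounds than this note shows. Statements on the series, on what has been measured and on what is new or still open speak of the compounds shown alone.

Going by the values given here, in an ADME assay on MRC5 cells (Homo sapiens) for antiproliferative activity, read by fluorescence and resazurin assay, with a stated time of 68 h (a lower number here means that less compound is needed, a higher number that more compound is needed for the effect), compound 1 (`Cc1ccc(-c2cc(C(=O)Nc3cccnc3)c3cc(Cl)ccc3n2)cc1`) gives 21000 nM and this is the only true number so far. Compound 2 (`Cc1ccc(-c2cc(C(=O)Nc3cccnc3)c3ccccc3n2)cc1`) reads > 50000 nM and this is a limit of the assay, not a number. Compound 1 therefore stands as the single quantified reference, on the lower side of that limit. Among the compounds with values here, the one measured step is an at least 2.3-fold higher number from compound 1 to compound 2 (0.37 log units; beyond the scatter) and it concerns only the chloro on the shared core, which compound 3 (`Cc1ccc(-c2cc(C(=O)NCCN3CCCC3)c3cc(Cl)ccc3n2)cc1`) keeps.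

The change now under study lies elsewhere: 2-(pyrrolidin-1-yl)ethyl in place of pyridin-3-yl on an amide-type nitrogen on an amide-type nitrogen whose other neighbour is the carbonyl carbon. Within the data shown here, no measured step touches this place, so the step from the chloro gives no size or direction for it. The working expectation is therefore no shift beyond the scatter in either direction, held with low confidence. The expected 1.4-fold lower number from compound 1 to compound 3 (0.15 log units; within the scatter) is small against the width of the range. Compound 3 is estimated at 15000 nM with an expected range from 5000 nM to 45000 nM in this assay as its reading is awaited.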

Compound 3, half-maximal effective concentration: 7000 nM
For compound 3 the middle estimate is 2.1-fold (0.33 log units) above the measured one, and the stated range covers the measured number.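

In this assay, the group on the amide-type nitrogen proves to be a place where the number responds: 2-(pyrrolidin-1-yl)ethyl in place of pyridin-3-yl gives a 3.0-fold lower number from compound 1 to compound 3 (0.48 log units; beyond the scatter). This adds a second site to the chloro on the shared core where a single change goes beyond the scatter, and here the number falls, with the chloro kept. The counted hydrogen-bond donors, hydrogen-bond acceptors and net charge are the same for both groups, so these counts do not separate them, and nothing measured here bears on the cause of the step.

Going by these compounds alone, the one step replaces the aromatic ring with a non-aromatic ring and adds the ethyl chain together, so it remains open whether the ring or the chain carries the shift, a question that a 2-(dimethylamino)ethyl group or a longer chain ending in pyrrolidine on the same nitrogen would address. Compound 2 reads > 50000 nM, which is a limit and not a number, and it offers no quantified base for judging how this change behaves on the core without the chloro.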